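The source may report more compounds than this note shows. Statements on the series, on what has been measured and on what is new or still open speak of the compounds shown alone.

Compounds measured in a functional assay on A2780 cells (Homo sapiens) for inhibition, read by sulforhodamine B assay, with a stated time of 96 h; on this read-out higher numbers stand for weaker inhibition of growth and lower numbers for stronger inhibition of growth:
- compound 1 `CC[C@@H](Nc1nc(NCc2ccccn2)c2ncn(C(C)C)c2n1)C(C)(C)O`: compound 1 gives > 50000 nM, which is a limit of the assay.
- compound 2 `CCC(O)[C@@H](CC)Nc1nc(NCc2ccccn2)c2ncn(C(C)C)c2n1`: compound 2 gives 40000 nM.
- compound 3 `CC[C@@H](Nc1nc(NCc2ccccn2)c2ncn(C(C)C)c2n1)C(O)C(C)(C)C`: compound 3 gives > 50000 nM, which is a limit of the assay.

Compound 1 stands only as a limit in this assay, and that is the limit of > 50000 nM in this assay, at which 2 of the 3 values shown sit. Its neighbours give little guidance on size: the step of an at least 1.2-fold lower number from compound 1 to compound 2 (0.09 log units; that floor lies within the scatter) has a floor within the scatter, the step that the two limits leave unreadable from compound 1 to compound 3 cannot be read, and the step of an at least 1.2-fold higher number from compound 2 to compound 3 (0.09 log units; that floor lies within the scatter) again has a floor within the scatter. Compound 4 `CC[C@H](Nc1nc(NCc2ccccn2)c2ncn(C(C)C)c2n1)C(C)(C)O` is not yet measured. It differs from compound 1 only as follows: the two compounds have the same atoms and bonds and differ only in configuration as drawn: 1 of 1 stereo elements differ; a stereocentre at a saturated chain carbon is drawn R in compound 1 and S in compound 4. Among the measured compounds shown here, none of the measured steps concerns a change in configuration; each of them exchanges a group on the chain, so no measured step bears directly on this change. With compound 1 at a limit and every measured value near or at that limit, compound 4 is expected to stay in the same weak region, and a step of an at least 1.1-fold lower number from compound 1 to compound 4 (0.04 log units; that floor lies within the scatter) is estimated, with a real chance that only a limit is again reported. Compound 4 is estimated at 45000 nM, between 10000 nM and 150000 nM.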

Compound 4, concentration for 50% growth inhibition: 44000 nM
For compound 4 the middle estimate is 1.0-fold (0.01 log units) above the measured one; the measured number falls inside the stated range.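

In this assay, drawing the stereocentre at the saturated chain carbon as S rather than R gives an at least 1.1-fold lower number from compound 1 to compound 4 (0.05 log units; that floor lies within the scatter), so this change in configuration shows no step beyond the scatter, although the true size remains hidden by the limit on one side. Compound 4 also stays level with the chain variants, with an at least 1.1-fold lower number from compound 3 to compound 4 (0.05 log units; that floor lies within the scatter) and a 1.1-fold higher number from compound 2 to compound 4 (0.04 log units; within the scatter), so neither of these exchanges on the nitrogen separates compound 4 from them by a readable margin. With the S form added, the series still sits at the weak end of this read-out, and the limit remains common: the limit of > 50000 nM in this assay, at which 2 of the 4 values shown sit.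

Going by these compounds, the actual size of the step from R to S stays open, as does whether this stereocentre would matter in a compound that inhibits growth more strongly. On these data alone, it is also open whether an amine or a carboxylic acid in place of the hydroxy group on the chain would move the number away from this weak region.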